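This account rests on a few compounds, and the source may have more. Where it says the series, first, only, none or still open, it means among the compounds named here.

Of the compounds shown here, three have been measured in a functional assay on A2780 cells (Homo sapiens) for cytotoxicity, read by sulforhodamine B assay, with a stated time of 72 h; a lower number here means a stronger inhibitor, a higher number a weaker inhibitor. Compound 1 `O=S(=O)(c1ccccc1)c1ccc(CNS(=O)(=O)N2Cc3ccncc3C2)cc1` reports only a limit, > 2000 nM, and not a number. In this assay compound 2 `CCCn1cc(S(=O)(=O)c2ccc(CNC(=O)N3Cc4ccncc4C3)cc2)cn1` gives 7.3 nM. Compound 3 `O=C(NCc1ccc(S(=O)(=O)C2CCOCC2)cc1)N1Cc2ccncc2C1` gives 35 nM, the higher of the two actual numbers. For the measured compounds named here, the only measured step on the sulfonyl sulfur is a 4.8-fold higher number from compound 2 to compound 3 (0.68 log units; beyond the scatter), and it bears directly on what follows. Compound 4 `O=C(NCc1ccc(S(=O)(=O)N2CCOCC2)cc1)N1Cc2ccncc2C1` has not yet been measured. Its difference from compound 3 is morpholin-4-yl in place of oxan-4-yl on a sulfonyl sulfur; in words, morpholin-4-yl in place of oxan-4-yl on a sulfonyl sulfur. The step from compound 2 replaced 1-propyl-1H-pyrazol-4-yl, whereas here one six-membered non-aromatic ring replaces another, so a smaller change is expected than that modest one, probably none beyond the scatter in either direction. The expected step is a 1.1-fold higher number from compound 3 to compound 4 (0.06 log units; within the scatter). For compound 4 the estimated value in this assay is 40 nM, with an expected range of 12 nM to 130 nM.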

Compound 4, half-maximal inhibitory concentration: 68 nM
Estimate against measurement, compound 4: 1.7-fold (0.23 log units) below, within the range that was stated.
By their numbers in this assay, from the lowest: compound 2; then compounds 3 and 4 (each within the scatter of the next). At a limit, above all of these: compound 1.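

In this assay, morpholin-4-yl and oxan-4-yl on a sulfonyl sulfur cannot be told apart (a 1.9-fold higher number from compound 3 to compound 4 (0.29 log units; within the scatter)), so at this position the two six-membered non-aromatic rings behave as one within the scatter. The 1-propyl-1H-pyrazol-4-yl group of compound 2 now stands apart from both rings, and the second step (a 9.3-fold higher number from compound 2 to compound 4 (0.97 log units; beyond the scatter)) shows that the earlier gap was not particular to oxan-4-yl. Nothing measured here gives a reason for either step.

As far as these compounds go, it remains open whether a piperazin-1-yl ring or an open-chain dimethylamino group on the sulfonyl sulfur would stay with these two rings or come closer to compound 2. From the compounds shown here alone, it is also open whether a methyl or butyl chain in place of the propyl chain on the pyrazole would keep the number of compound 2.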